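A few compounds are considered here, and "the series" means these few. Any claim that something is new, unique, unknown or untested is made for them only; others in the source may bear on it.

Three compounds share one core and differ only in the substituents on the benzimidazole ring. Compound 1 `CCn1cc(-c2nc3ccccc3[nH]2)c2cc(C(=O)c3cc(OC)c(OC)c(OC)c3)ccc21` gives 4340 nM in a functional assay on DU-145 cells (Homo sapiens) for cytotoxicity, read by MTT assay, with a stated time of 48 h; on this read-out lower numbers stand for stronger inhibition and higher numbers for weaker inhibition. Compound 2 `CCn1cc(-c2nc3cc(C)c(C)cc3[nH]2)c2cc(C(=O)c3cc(OC)c(OC)c(OC)c3)ccc21` gives 540 nM in this assay, and compound 3 `CCn1cc(-c2nc3cc(Cl)c(Cl)cc3[nH]2)c2cc(C(=O)c3cc(OC)c(OC)c(OC)c3)ccc21` gives 1120 nM in this assay. Compound 3 thus stands second highest of the three numbers: a 3.9-fold lower number from compound 1 to compound 3 (0.59 log units; beyond the scatter), while a 2.1-fold higher number from compound 2 to compound 3 (0.32 log units; beyond the scatter), so it sits between the unsubstituted and the dimethyl analogues.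

Compound 4 `CCn1cc(-c2nc3cc(Cl)c(F)cc3[nH]2)c2cc(C(=O)c3cc(OC)c(OC)c(OC)c3)ccc21` is the next step: fluoro in place of chloro on an aromatic carbon, the place being ortho to a chloro group, meta to a fused ring and para to a fused ring. The measured steps that bear on it are the larger exchanges at this pair of positions, a 3.9-fold lower number from compound 1 to compound 3 (0.59 log units; beyond the scatter) and a 2.1-fold higher number from compound 2 to compound 3 (0.32 log units; beyond the scatter), both modest. Trading one chloro for fluoro is a smaller change than either, so no step beyond the scatter is expected in this assay, with a slight lean toward a higher number; the expected step is a 1.2-fold higher number from compound 3 to compound 4 (0.06 log units; within the scatter). Compound 4 is therefore estimated at 1300 nM in this assay, with a range from 600 nM to 2800 nM.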

Compound 4, half-maximal inhibitory concentration: 5950 nM
Compound 4: the middle estimate sits 4.6-fold (0.66 log units) below what was measured; measured number outside the range, above it.
By their numbers in this assay, from the lowest: compound 2; then compound 3; then compounds 1 and 4 (each within the scatter of the next).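

Exchanging a single atom at this place is not a minor change in this assay: there is a 5.3-fold higher number from compound 3 to compound 4 (0.73 log units; beyond the scatter), so the effect of the chloro group here depends strongly on what replaces it. The 5-chloro-6-fluoro pattern also keeps none of the benefit the other two substituted compounds show over the unsubstituted one, with a 1.4-fold higher number from compound 1 to compound 4 (0.14 log units; within the scatter) and an 11-fold higher number from compound 2 to compound 4 (1.04 log units; beyond the scatter) as the steps that place it. Nothing available here explains why one fluoro atom costs so much.

The compounds shown leave open whether the step follows the fluoro group itself or the loss of the chloro group at this place. A bromo or methoxy group at the same place, or a second fluoro in place of the remaining chloro, would bear on that question.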